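This account rests on a few compounds, and the source may have more. Where it says the series, first, only, none or still open, it means among the compounds named here.

Measured so far:
- compound 1 `O=C(Nc1ccc(F)cc1)Nc1cccc(CNc2ncnc3ccccc23)c1`: 44300 nM
- compound 2 `COc1cc2ncnc(NCc3cccc(NC(=O)Nc4ccccc4)c3)c2cc1OC`: 10000 nM

In a functional assay on MGC-803 cells (Homo sapiens) for antiproliferative activity, read by MTT assay (on this read-out lower numbers stand for stronger inhibition and higher numbers for weaker inhibition), compound 2 gives 10000 nM, the lowest of the two numbers recorded. In this assay compound 1 gives 44300 nM, a higher number that lies beyond the usual scatter of such measurements, so compound 2 is the more active of the two. Compound 3 `COc1cc2ncnc(NCc3cccc(NC(=O)Nc4ccc(C(C)(C)C)cc4)c3)c2cc1OC` has not yet been measured. It differs from compound 2 in one place: tert-butyl in place of hydrogen on an aromatic carbon. Within the data shown here, no measured pair shows this exact change, so its effect cannot be read from the numbers at hand. A change of this kind is expected to shift the number only modestly, most likely downward, and the step from compound 2 to compound 3 is estimated as a 2.0-fold lower number from compound 2 to compound 3 (0.30 log units; within the scatter). Compound 3 is therefore expected to give about 5000 nM in this assay, within a range from 1500 nM to 20000 nM.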

Compound 3, half-maximal inhibitory concentration: 6790 nM
The estimate for compound 3 lay 1.4-fold (0.13 log units) below the measured number, and the stated range covers the measured number.
By their numbers in this assay, from the lowest: compounds 3 and 2 (each within the scatter of the next); then compound 1.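

In this assay, tert-butyl in place of hydrogen on an aromatic carbon, para to a large group, gives a 1.5-fold lower number from compound 2 to compound 3 (0.17 log units; within the scatter). Among these compounds, this is the first single-place comparison, and it shows that this carbon can carry a group of 4 heavy atoms, with no ring, while the number stays within the usual scatter of the one for the hydrogen compound. Nothing measured here offers an explanation for this result.

As far as these compounds go, whether an amine, a carboxylic acid or a longer chain on this same carbon would also leave the number within the scatter remains open. Fluorine on this ring appears only in compound 1, whose core also differs, so the effect of that atom alone cannot be read from these compounds.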